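Dimethylsulfamoyl added to the phenyl of compound 3

The source may report more compounds than this note shows. Statements on the series, on what has been measured and on what is new or still open speak of the compounds shown alone.

Three members of the series have numbers in an assay on microsomes from brain for inhibition of Fatty-acid amide hydrolase 1 (Rattus norvegicus), read by fluorescence and HPLC, with a stated time of 60 min; a higher number here means a weaker inhibitor, a lower number a stronger inhibitor. Compound 1 `CCCCCCCCc1ccc(OCC(=O)Cn2nnc(SC)n2)cc1` gives 31 nM. Compound 2 `CCCCCCCCc1ccc(OCC(=O)Cn2nnc(-c3cccc(S(=O)(=O)N(C)C)c3)n2)cc1` gives 420 nM. Compound 3 `CCCCCCCCc1ccc(OCC(=O)Cn2nnnc2-c2ccccc2)cc1` gives 71 nM, the second highest of the three: compound 1 sits below it and compound 2 above it, both gaps beyond the scatter.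

Compound 4 `CCCCCCCCc1ccc(OCC(=O)Cn2nnnc2-c2ccc(S(=O)(=O)N(C)C)cc2)cc1` is not yet measured. It differs from compound 3 by dimethylsulfamoyl in place of hydrogen on an aromatic carbon. Going by the values given here, the only measured step that bears on this is a 14-fold higher number from compound 1 to compound 2 (1.13 log units; beyond the scatter); there, however, a 3-(dimethylsulfamoyl)phenyl replaced the whole methylsulfanyl group, so that step bundles a phenyl with the sulfonamide. Compound 1 and compound 3 show what a phenyl alone does when set differently on the shared core: compound 3 has the higher number, with a gap beyond the scatter. The step from compound 3 to compound 4 is therefore expected to be upward and beyond the scatter, yet smaller than the step from compound 1 to compound 2, since the place of the dimethylsulfamoyl on the phenyl also differs from compound 2. Compound 4 is expected at 250 nM, between 80 nM and 800 nM. That estimate corresponds to an expected step of a 3.5-fold higher number from compound 3 to compound 4 (0.55 log units; beyond the scatter) in this assay.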

Compound 4, half-maximal inhibitory concentration: 1400 nM
Compound 4: middle estimate off by 5.6-fold (0.75 log units), on the low side; measured number above the stated range.
By their numbers in this assay, from the lowest: compound 1; then compound 3; then compound 2; then compound 4.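

Going by these compounds alone, the single change a 20-fold higher number from compound 3 to compound 4 (1.29 log units; beyond the scatter) in this assay leaves the phenyl in place, so the rise in the number here belongs to dimethylsulfamoyl alone, para to a large group, and not to a bundle of phenyl and sulfonamide such as the one in the step of a 14-fold higher number from compound 1 to compound 2 (1.13 log units; beyond the scatter). Within the data shown here, of the four compounds, the two that carry dimethylsulfamoyl have the two highest numbers, compound 2 with 420 nM and compound 4 with 1400 nM in this assay, on phenyl rings set differently on the shared core, and no compound in the set goes against this. Nothing measured on these compounds accounts for the size of the step.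

The compounds shown leave open whether a smaller group at the same place on the phenyl of compound 3, such as methyl, fluorine or an unsubstituted sulfonamide, would raise the number as far, and whether a carboxylic acid or an amine there would do the same. They also leave open how a 3-(dimethylsulfamoyl)phenyl would read on the core of compound 3, which would separate the place of the group from the setting of the phenyl.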